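Methyl for hydrogen on a triazole series in the electroshock model

This account rests on a few compounds, and the source may have more. Where it says the series, first, only, none or still open, it means among the compounds named here.

The measured compounds:
compound 1, `Cn1c(-c2ccccc2)nnc1[S+](C)[O-]`, > 100 mg/kg;
compound 2, `CC[S+]([O-])c1nnc(-c2ccccc2)n1C`, > 200 mg/kg;
compound 3, `CSc1nnc(-c2ccc(Cl)cc2)n1C`, > 200 mg/kg.

In a functional assay on the whole organism for antagonist activity, with Mus musculus as the target, in the maximal electroshock model (a higher number here means that more compound is needed for the effect, a lower number that less compound is needed), compound 1 reaches only a limit, > 100 mg/kg. Compound 2 also gives only a limit in this assay, > 200 mg/kg. The change between them is methyl in place of hydrogen on a saturated chain carbon bound to a sulfur, and the step that the two limits leave unreadable from compound 1 to compound 2 cannot be sized, because both values are limits, as the limit of > 100 mg/kg in this assay, at which 1 of the 3 values shown sits, and the limit of > 200 mg/kg in this assay, at which 2 of the 3 values shown sit, show. Compound 3 likewise gives only a limit in this assay, > 200 mg/kg. The difference between the core of compound 1 and the core of compound 3 is not broken down here.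

Compound 4, `CCn1c(SC)nnc1-c1ccc(Cl)cc1`, is not yet measured. It differs from compound 3 by methyl in place of hydrogen on a saturated chain carbon bound to an aromatic nitrogen. This is the same kind of change as that from compound 1 to compound 2, but the place differs: there it sits on a saturated chain carbon bound to a sulfur, here on a saturated chain carbon bound to an aromatic nitrogen. Since the step from compound 1 to compound 2 is unreadable, no size for it can be carried over. The expected step from compound 3 to compound 4 is therefore estimated at a step that the limit leaves unreadable from compound 3 to compound 4, resting on the limit of compound 3 alone. Compound 4 is expected to give about 250 mg/kg, within 100 mg/kg to 600 mg/kg, most likely again as a limit.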

Compound 4, dose for half-maximal effect: > 50 mg/kg
Compound 4: only a limit was reported; the forecaster's own chance of this, stated with the estimate: 70%; the middle value lies beyond the limit too.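

Compound 4 gives only a limit in this assay, > 50 mg/kg. Compound 3 also stands only as a limit, so the step between compound 3 and compound 4 cannot be read. The compounds shown leave open whether methyl in place of hydrogen, at either place, changes the dose needed, as all four values are limits.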